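A few compounds are considered here, and "the series" means these few. Any claim that something is new, unique, unknown or untested is made for them only; others in the source may bear on it.

Compound 1, `COc1cccc(Oc2ccc3c(NCCCNCc4ccco4)ccnc3c2)c1`: 9.28
Compound 2, `c1ccc(Cc2ccc3c(NCCCNCc4ccco4)ccnc3c2)cc1`: 9.47
Compound 3, `COc1ccc(F)cc1CNCCCNc1ccnc2cc(Cc3ccccc3)ccc12`: 9.47

All three numbers come from a physicochemical assay for acid dissociation. Compound 3 stands level with compound 2 at the digits shown, and together they are the highest of the three values; compound 1 sits a little lower, but both steps between neighbours, a number 0.19 log units higher from compound 1 to compound 2 (within the scatter) and no change at the digits printed from compound 2 to compound 3 (within the scatter), stay within the scatter.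

Compound 4, `COc1ccc(F)cc1CNCCCNc1ccnc2cc(Oc3ccccc3OC)ccc12`, differs from compound 3 in one place: 2-methoxyphenoxy in place of benzyl on an aromatic carbon. Going by the values given here, the one earlier step that bears on this, a number 0.19 log units higher from compound 1 to compound 2 (within the scatter), was a swap of the same kind run in the opposite direction, and it stayed within the scatter. A step of similar size is therefore expected, if anything slightly downward, as a number 0.17 log units lower from compound 3 to compound 4 (within the scatter). For compound 4 the estimate is 9.3, between 9 and 9.6.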

Compound 4, acid dissociation constant: 9.28
The estimate for compound 4 lay 0.02 log units above the measured number; the measured number falls inside the stated range.
By their numbers in this assay, from the lowest: compounds 1, 4, 2 and 3 (each within the scatter of the next).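

In this assay, putting 2-methoxyphenoxy in place of benzyl on this aromatic carbon gives a number 0.19 log units lower from compound 3 to compound 4 (within the scatter). The earlier swap at this position involved 3-methoxyphenoxy and a furan-2-yl side chain, so this step shows that the read-out also stays within the scatter with a different methoxyphenoxy group and with the 5-fluoro-2-methoxyphenyl side chain. No other measurement here bears on this result. From the compounds shown here alone, it remains open whether a quite different group at this position, such as an amine or a carboxylic acid, would shift the number beyond the scatter.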